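From a Branched to a Straight Three-Carbon Chain

This account rests on a few compounds, and the source may have more. Where it says the series, first, only, none or still open, it means among the compounds named here.

Measured compounds:
compound 2 `Cc1nc(N)c2c(n1)N(Cc1ccccc1)C(=O)NC2`: 1.6
compound 3 `CC(C)c1cc2c([nH]c(=O)n2Cc2ccccc2)c(N)n1`: 3.1

Compound 1 `Cc1nc(N)c2sc(=O)n(Cc3ccccc3)c2n1` is "not determined" (no result reported) in a physicochemical assay for lipophilicity, measured as octanol-water partition, at pH 7.4 (on this read-out higher numbers stand for higher lipophilicity and lower numbers for lower lipophilicity), so no result exists for it there. Among the two numbers that exist in this assay, compound 3 stands highest: compound 2 lies lower, and that gap is beyond the usual scatter. Compound 4 `CCCc1cc2c([nH]c(=O)n2Cc2ccccc2)c(N)n1` is the next step from compound 3, and the two share every atom, joined differently: propyl in place of isopropyl on an aromatic carbon. Among the compounds with values here, no pair of measured compounds shows such a propyl-for-isopropyl exchange, so its effect is untested here. For a change of this kind, the expected step of a number 0.10 log units higher from compound 3 to compound 4 (within the scatter) is small, lying within the scatter. Compound 4 is therefore estimated at 3.2, in a range from 2.8 to 3.6.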

Compound 4, distribution coefficient: 3.1
Compound 4: the middle estimate sits 0.10 log units above what was measured, within the range that was stated.
By their numbers in this assay, from the lowest: compound 2; then compounds 3 and 4 (each within the scatter of the next).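

In this assay, within the data shown here, the exchange of isopropyl for propyl on this aromatic carbon gives no change at the digits printed from compound 3 to compound 4 (within the scatter) as the first measured step at this position. For this one pair, joining the same three carbons as a straight chain rather than a branched one leaves the read-out without a visible shift. Nothing available here explains this result. Still open, as far as these compounds go, is how a longer chain such as butyl, or a carboxylic acid, would read at this carbon. A single pair also leaves open whether the same exchange would give a similar result on a different core.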